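The source may report more compounds than this note shows. Statements on the series, on what has been measured and on what is new or still open speak of the compounds shown alone.

Measured compounds:
compound 1 `CC(C)(C)c1ccc(CNC(=O)NCCCCl)cc1` — 11000 nM
compound 2 `O=C(CCl)Nc1ccc(I)cc1` — 5100 nM
compound 3 `CC(C)(C)c1ccc(NC(=O)CCl)cc1` — 5400 nM

Of the compounds shown here, three have been measured in a functional assay on M21 cells (Homo sapiens) for antiproliferative activity, with a stated time of 48 h; on this read-out lower numbers stand for stronger inhibition and higher numbers for weaker inhibition. Compound 2 gives the lowest of the three numbers. Its nearest neighbour is compound 3, reached by a 1.1-fold higher number from compound 2 to compound 3 (0.02 log units; within the scatter), a step that stays within the scatter, so no order between compound 2 and compound 3 can be read. Compound 1 stands furthest away, with a number that lies beyond the scatter above that of compound 2.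

The unmeasured compound 4 `O=C(CCCCl)Nc1ccc(I)cc1` differs from compound 2 by 2-chloroethyl in place of chloro on a saturated chain carbon bound to a carbonyl carbon. For the measured compounds named here, no measured step covers a change of this kind: the only step recorded, from compound 2 to compound 3, concerns the substituent on the aromatic carbon, not the chlorine-bearing chain. Going by the values given here, the only hint comes from compound 1, whose longer chain beside the carbonyl goes with a higher number than compound 3 shows, though these two compounds differ in more than one place. On that thin basis a modest shift toward a higher number is expected in this assay, though a result within the scatter would not surprise. Compound 4 is therefore expected to give 14000 nM (range 5000 nM to 40000 nM), which corresponds to an estimated step of a 2.7-fold higher number from compound 2 to compound 4 (0.44 log units; beyond the scatter).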

Compound 4, half-maximal inhibitory concentration: > 100000 nM
Compound 4: no number, only a limit; the forecaster's own chance of this, stated with the estimate: 10%; at least 7.1-fold (0.85 log units) between middle value and limit.
By their numbers in this assay, from the lowest: compounds 2 and 3 (each within the scatter of the next); then compound 1. At a limit, above all of these: compound 4.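

In this assay compound 4 gives > 100000 nM, which is a limit of the assay and not a number. Even read as a limit, 2-chloroethyl in place of chloro on a saturated chain carbon bound to a carbonyl carbon is a large change, an at least 19-fold higher number from compound 2 to compound 4 (1.29 log units; beyond the scatter), and it is the first step shown at this position. The only earlier step, a 1.1-fold higher number from compound 2 to compound 3 (0.02 log units; within the scatter), concerned an aromatic carbon and stayed within the scatter, so this chain position is the one place where a single change has so far moved the number, and the value reached stands alone in the set: the limit of > 100000 nM in this assay, at which 1 of the 4 values shown sits.

The compounds shown do not tell whether this result follows from the length of the chain as such or from where the chlorine ends up on it, since they include neither the intermediate 2-chloroethyl chain on that carbonyl nor a plain propyl chain without chlorine. As far as these compounds go, it also remains open whether an amine or a hydroxyl in place of the chlorine would be tolerated, and whether the same chain change would give a similar result with tert-butyl on the aromatic carbon.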